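The source may report more compounds than this note shows. Statements on the series, on what has been measured and on what is new or still open speak of the compounds shown alone.

Of the compounds shown here, two have been tested so far. Compound 1 `c1ccc(-c2nc3sc(-c4ccccc4)cn3n2)cc1` gives 9% in a functional assay on HT-29 cells (Homo sapiens) for inhibition, read by sulforhodamine B assay, with a stated time of 48 h, tested at 10 uM; a lower number here means less inhibition of growth, a higher number more inhibition of growth at the concentration tested. Compound 2 `C/C(=N/O)c1ccc(NC(=O)Cn2nc(C(F)(F)F)nc2N)cc1`, built on a different framework, gives 11.9% in this assay. The two numbers sit within the usual scatter of each other, so neither compound can be separated from the other on this evidence, and both show only weak inhibition of growth at the concentration tested.

Compound 3 `Clc1ccc(-c2cn3nc(-c4ccccc4)nc3s2)cc1` has not been measured yet. It differs from compound 1 in one place: chloro in place of hydrogen on an aromatic carbon. Otherwise the shared core and the rest of the molecule are unchanged.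

Within the data shown here, no step between two measured compounds is available to guide this change. With compound 1 at 9%, the step of a number 6 percentage points higher from compound 1 to compound 3 (within the scatter) is expected to be small, at most a modest rise barely beyond the scatter. Compound 3 is therefore estimated at 15%, with a likely range from 3% to 32%.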

Compound 3, percent growth inhibition at one concentration: 26%
Estimate against measurement, compound 3: 11 percentage points below; the range from low to high includes it.
By their numbers in this assay, from the lowest: compounds 1 and 2 (each within the scatter of the next); then compound 3.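

Replacing hydrogen with chloro, para to a large group on a six-membered aromatic ring of carbon only, gives a number 17 percentage points higher from compound 1 to compound 3 (beyond the scatter) in this assay. Among these compounds, this is the first change in the set whose effect can be read, and it shows that the position responds to substitution: one chlorine atom, adding no hydrogen-bond donors or acceptors, moves growth inhibition clear of the usual scatter, although the step is only modest. No measurement available here explains the rise, so the phenyl to 4-chlorophenyl change can be recorded but not accounted for.

From the compounds shown here alone, it remains open whether fluoro, methyl or methoxy at this place would give a similar step, or whether an amine or a carboxylic acid would behave differently. Also unresolved is whether chloro on the other phenyl ring would change the number to a similar extent.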